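The compounds below may be only part of what the source reports. "The series", "measured", "known", "first", "only" and "open" are said of these compounds alone.

Working notes on the terminal aryl amide of the shared core

The core is that of compound 1 `Cc1ccc(S(=O)(=O)N[C@@H](CC(=O)NC(C)(C)C)C(=O)NCCNC(=O)c2ccccc2)cc1`, closed at the chain end by an unsubstituted benzoyl amide; compound 2 `Cc1ccc(S(=O)(=O)N[C@@H](CC(=O)NC(C)(C)C)C(=O)NCCNC(=O)c2ccccc2F)cc1` and compound 3 `C#Cc1cccc(C(=O)NCCNC(=O)[C@H](CC(=O)NC(C)(C)C)NS(=O)(=O)c2ccc(C)cc2)c1` differ from it only on that aryl. In an ADME assay on HepG2 cells (Homo sapiens) for cytotoxicity (a lower number here means that less compound is needed, a higher number that more compound is needed for the effect), compound 1 gives > 11000 nM, which is a limit of the assay and not a number. Compound 2 also returns only the limit > 11000 nM in this assay. Compound 3 likewise stops at the limit > 11000 nM. The steps a step that the two limits leave unreadable from compound 1 to compound 2, a step that the two limits leave unreadable from compound 1 to compound 3 and a step that the two limits leave unreadable from compound 2 to compound 3 are therefore unreadable in size, since all three values share (the limit of > 11000 nM in this assay, at which 3 of the 3 values shown sit). Compound 2 thus stands where every measured member stands: at the limit, with no number to place it higher or lower than the others.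

Compound 4 `Cc1ccc(S(=O)(=O)N[C@@H](CC(=O)NC(C)(C)C)C(=O)NCCNC(=O)c2ccccc2O)cc1` is the next variation on the same aryl. The change from compound 2 is hydroxy in place of fluoro on an aromatic carbon. Among the measured compounds shown here, no measured step bears on this exchange in readable size; both earlier aryl changes left the read-out at the limit. The step expected from compound 2 to compound 4, a step that the limit leaves unreadable from compound 2 to compound 4, is thus estimated as none beyond the scatter. Compound 4 is expected to give about 15000 nM in this assay, most likely reported again as a limit, with an estimated range from 8000 nM to 40000 nM.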

Compound 4, half-maximal effective concentration: > 11000 nM
Compound 4 gave a limit, no number; the forecaster's own chance of this, stated with the estimate: 85%; the middle value does not contradict the limit.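

Compound 4 ends at a limit in this assay, as do compound 1, compound 2 and compound 3, so none of the steps to compound 4 can be read in size: the limit of > 11000 nM in this assay, at which 4 of the 4 values shown sit.

The compounds shown leave open whether any change on this aryl of the shared core moves the read-out in this assay at all.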